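Benzyl in place of cyclopropylmethyl on the amine arm

A few compounds are considered here, and "the series" means these few. Any claim that something is new, unique, unknown or untested is made for them only; others in the source may bear on it.

Compound 1 `Cc1cc(C)c(-n2c(Cl)cn3c(CN(CCC(F)(F)F)CC4CC4)c(C(F)(F)F)nc23)c(C)c1` stands second highest of the three numbers available in an assay on cells for displacement of a labelled ligand from corticotropin-releasing factor receptor 1 (Homo sapiens), with a stated time of 100 min (on this read-out higher numbers stand for weaker inhibition and lower numbers for stronger inhibition), where compound 1 gives 16 nM. Its closest neighbour is compound 3 `CCN(CCC1CC1)Cc1c(C(F)(F)F)nc2n(-c3c(C)cc(C)cc3C)c(Cl)cn12`, which in this assay gives 13 nM; the gap a 1.2-fold lower number from compound 1 to compound 3 (0.09 log units; within the scatter) is within the scatter. Furthest away is compound 2 `C=C(C)CN(CC)Cc1c(C(F)(F)F)nc2n(-c3c(C)cc(C)cc3C)c(Cl)cn12`, which gives 67 nM; the step of a 4.2-fold higher number from compound 1 to compound 2 (0.62 log units; beyond the scatter) is beyond the scatter, as is the step of a 5.2-fold lower number from compound 2 to compound 3 (0.71 log units; beyond the scatter).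

Compound 4 `Cc1cc(C)c(-n2c(Cl)cn3c(CN(CCC(F)(F)F)Cc4ccccc4)c(C(F)(F)F)nc23)c(C)c1` differs from compound 1 by phenyl in place of cyclopropyl on a saturated chain carbon bound to an amine nitrogen. Read one bond further out, this is cyclopropylmethyl to benzyl. Among the measured compounds shown here, none of the measured steps changes a cyclopropyl into a phenyl, so they bear on the new compound only loosely: they show that the amine arm of the shared core tolerates exchanges between small saturated or unsaturated chains, with the swap in compound 2 being the one that costs potency. A phenyl is a larger change than any of these, and the direction cannot be read from the data.

For compound 4 the expectation is therefore a step of a 1.9-fold higher number from compound 1 to compound 4 (0.27 log units; within the scatter), towards a slightly higher number, with an estimated value of 30 nM and a range from 10 nM to 100 nM.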

Compound 4, inhibition constant: 43 nM
Beside the measured number, compound 4's estimate is 1.4-fold (0.16 log units) below it; the measured number falls inside the stated range.
By their numbers in this assay, from the lowest: compounds 3 and 1 (each within the scatter of the next); then compounds 4 and 2 (each within the scatter of the next).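

Among the compounds shown here, compound 4 is the first in the set to carry an aromatic ring on the amine arm, and the exchange gives a 2.7-fold higher number from compound 1 to compound 4 (0.43 log units; beyond the scatter) in this assay. So this carbon bound to the amine nitrogen accepts phenyl in place of cyclopropyl, with a modest loss rather than a collapse of binding, while compound 4, like compound 1, keeps the 3,3,3-trifluoropropyl arm and the rest of the shared core unchanged. Nothing available explains why the number moves in this direction for this exchange.

The single step changes ring size and aromatic character together, so the compounds shown leave open whether cyclohexyl, a saturated six-membered ring, would read like phenyl or like cyclopropyl. They also leave open how far this arm can grow or vary, for instance with a 2-phenylethyl group, which holds the ring one carbon further out, or with a pyridyl ring, which places a ring nitrogen where phenyl has only carbon.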